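A few compounds are considered here, and "the series" means these few. Any claim that something is new, unique, unknown or untested is made for them only; others in the source may bear on it.

Measured compounds:
compound 1, `COc1ccc(-n2cc(COc3c(/C=C\C(=O)O)ccc(OC)c3CC=C(C)C)nn2)cc1`, 10200 nM
compound 2, `COc1ccc(/C=C\C(=O)O)c(OCc2cn(-c3cccc([N+](=O)[O-])c3)nn2)c1CC=C(C)C`, "not determined" (no result reported)
compound 3, `COc1ccc(/C=C\C(=O)O)c(OCc2cn(-c3cccc(C#N)c3)nn2)c1CC=C(C)C`, "not determined" (no result reported)

Compound 1 was tested in a functional assay on A549 cells (Homo sapiens) for cytotoxicity, read by MTT assay, with a stated time of 24 h (a lower number here means a stronger inhibitor, a higher number a weaker inhibitor), and gives 10200 nM, a weak effect. In this assay compound 2 is recorded as "not determined" (no result reported) and compound 3 as "not determined" (no result reported), so compound 3 stands without a value and cannot be placed against compound 1 or compound 2. Compound 4, `COc1ccc(/C=C\C(=O)O)c(OCc2cn(-c3ccc(C#N)cc3)nn2)c1CC=C(C)C`, differs from compound 3 only in this change: 4-cyanophenyl in place of 3-cyanophenyl on an aromatic nitrogen. For the measured compounds named here, with no measured step between any two compounds, no direction is indicated; the only anchor is the weak value of compound 1, and the change here is small. The expectation for compound 4 is therefore a similarly weak value, with a wide range: 12000 nM, between 3000 nM and 50000 nM.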

Compound 4, half-maximal inhibitory concentration: 42200 nM
Beside the measured number, compound 4's estimate is 3.5-fold (0.55 log units) below it, and the stated range covers the measured number.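

In this assay, cyano in place of methoxy on an aromatic carbon gives a 4.1-fold higher number from compound 1 to compound 4 (0.62 log units; beyond the scatter), the first measured sign that the group on this aromatic ring changes the result, with the cyano compound the weaker of the two. No measurement offered here explains this shift. The step between 3-cyanophenyl and 4-cyanophenyl cannot be read, as compound 3 has no value.

On these data alone, it remains open whether 3-cyanophenyl differs from 4-cyanophenyl at all. Also open, as far as these compounds go, is how an amine or a fluorine atom would compare with cyano and methoxy on this ring.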